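The source may report more compounds than this note shows. Statements on the series, on what has been measured and on what is new or still open speak of the compounds shown alone.

In a functional assay on the whole organism with Rattus norvegicus as the target (on this read-out lower numbers stand for an effect already at smaller amounts and higher numbers for an effect only at larger amounts of compound), compound 3 `N=c1sc2cc(OC(F)(F)F)ccc2n1CC(N)=O` gives 7 mg/kg, the highest of the two numbers shown, while compound 1 `CC(C)(C)c1ccc2nc(N)sc2c1` gives 4 mg/kg, a gap that lies within the usual scatter, so neither is called the stronger. Compound 2 `CCC(C)(C)c1ccc2nc(N)sc2c1` reaches only a limit of the assay, > 10 mg/kg. Among the compounds with values here, the single measured step, an at least 2.5-fold higher number from compound 1 to compound 2 (0.39 log units; beyond the scatter), concerns a position that compound 4 leaves untouched. Compound 4 `N=c1sc2cc(OC(F)(F)F)ccc2n1CCSc1ccccc1` differs from compound 3 by (phenylsulfanyl)methyl in place of carbamoyl on a saturated chain carbon bound to an aromatic nitrogen. Within the data shown here, since no measured step covers that position, the growth of a small group in compound 2 offers only a faint hint that a larger group may raise the number. Compound 4 is therefore expected to give about 8 mg/kg, between 3 mg/kg and 25 mg/kg, an estimated 1.1-fold higher number from compound 3 to compound 4 (0.06 log units; within the scatter) carrying wide uncertainty.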

Compound 4, dose for half-maximal effect: 4.5 mg/kg
The estimate for compound 4 lay 1.8-fold (0.25 log units) above the measured number; the range from low to high includes it.
By their numbers in this assay, from the lowest: compounds 1, 4 and 3 (each within the scatter of the next). At a limit, above all of these: compound 2.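

Swapping carbamoyl for (phenylsulfanyl)methyl on the saturated chain carbon bound to an aromatic nitrogen gives a 1.6-fold lower number from compound 3 to compound 4 (0.19 log units; within the scatter) in this assay. At this place, then, the hydrogen-bond donor of carbamoyl can go and a much larger group with a six-membered aromatic ring can enter, while the number stays within the scatter. Nothing measured here offers a reason for this result. As far as these compounds go, whether an amine or a carboxylic acid at this place would move the number beyond the scatter remains open. So does what an oxygen in place of the sulfur would do.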